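This account rests on a few compounds, and the source may have more. Where it says the series, first, only, none or still open, it means among the compounds named here.

Measured so far in a functional assay on Hep 3B2 cells (Homo sapiens) for inhibition, read by MTT assay, with a stated time of 72 h; on this read-out higher numbers stand for weaker inhibition and lower numbers for stronger inhibition
- compound 1 `Nc1ncnc2c1c(-c1cnc3[nH]ccc3c1)nn2CCCCCCC(=O)NO` gives 26300 nM
- compound 2 `Nc1nc2cc(-c3nn(CCCCCCCCC(=O)NO)c4ncnc(N)c34)ccc2o1` gives 8890 nM

Compound 2 has the lower number of the two at 8890 nM and so shows the stronger inhibition. Compound 1 sits higher at 26300 nM and the gap between them lies beyond the usual scatter. These two compounds differ in more than one place, so their gap cannot be tied to any single change.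

Compound 3 `Nc1nc2cc(-c3nn(CCCCCCC(=O)NO)c4ncnc(N)c34)ccc2o1` has not yet been measured. It differs from compound 2 in one place only hydroxycarbamoyl in place of 2-(hydroxycarbamoyl)ethyl on a saturated chain carbon, six bonds along the chain from an aromatic nitrogen with hydroxycarbamoyl in place of 2-(hydroxycarbamoyl)ethyl on a saturated chain carbon, six bonds along the chain from an aromatic nitrogen. The chain ending in the hydroxycarbamoyl group therefore becomes shorter.

Among the compounds with values here, no measured pair isolates this change, so the forecast is uncertain. A modest move toward a higher number, meaning weaker inhibition, is expected in this assay and may not clear the scatter by much. The estimated change is a 1.6-fold higher number from compound 2 to compound 3 (0.20 log units; within the scatter) and remains only an expectation. For compound 3 the expected value is 14000 nM with an estimated range from 4500 nM to 40000 nM until a measurement is available.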

Compound 3, half-maximal inhibitory concentration: 14000 nM
Estimate against measurement, compound 3: no gap at the digits printed; the range from low to high includes it.
By their numbers in this assay, from the lowest: compounds 2, 3 and 1 (each within the scatter of the next, the first and the last beyond it).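

Replacing 2-(hydroxycarbamoyl)ethyl with hydroxycarbamoyl on a saturated chain carbon, six bonds along the chain from an aromatic nitrogen, shortens the chain and gives (a 1.6-fold higher number from compound 2 to compound 3 (0.20 log units; within the scatter)) in this assay, so this change does not clearly separate the two compounds. Within the data shown here, compound 3 also carries the same chain as compound 1, which lets the group on the aromatic carbon of the shared core be read on its own for the first time, and that swap gives (a 1.9-fold lower number from compound 1 to compound 3 (0.27 log units; within the scatter)) , so it too stays unresolved. The gap between compound 1 and compound 2, which lies beyond the scatter, can therefore be split into two single changes, the chain and the aromatic group, and neither one clears the scatter alone.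

Nothing available here says why these numbers fall as they do. Still open, from the compounds shown here alone, is whether a chain longer than that of compound 2, or a carboxylic acid in place of the hydroxycarbamoyl group at the chain end, would move the number beyond the scatter in this assay.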